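Moving the Ring Nitrogen of a Pyridinylamino Substituent

A few compounds are considered here, and "the series" means these few. Any claim that something is new, unique, unknown or untested is made for them only; others in the source may bear on it.

Measured compounds:
compound 1, `COC(=O)c1sc2cc(Nc3ccccc3Br)cnc2c1N`: 28900 nM in a functional assay on MCF7 cells (Homo sapiens) for inhibition, read by sulforhodamine B assay, with a stated time of 48 h; on this read-out higher numbers stand for weaker inhibition of growth and lower numbers for stronger inhibition of growth
compound 2, `COC(=O)c1sc2cc(Nc3ccc4[nH]ccc4c3)cnc2c1N`: 18100 nM in this assay
compound 3, `COC(=O)c1sc2cc(Nc3ccccn3)cnc2c1N`: > 150000 nM in this assay, a limit of the assay rather than a number

Compound 3 is the only one of the three for which this assay gives no number, only the limit (the limit of > 150000 nM in this assay, at which 1 of the 3 values shown sits). Of the measured steps, one bears on it directly: an at least 5.1-fold higher number from compound 1 to compound 3 (0.71 log units; beyond the scatter). Going by these compounds, that step weakened growth inhibition beyond the scatter, and its true size is unknown, since compound 3 has only a limit.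

Compound 4, `COC(=O)c1sc2cc(Nc3cccnc3)cnc2c1N`, keeps everything of compound 3 except the change (pyridin-3-yl in place of pyridin-2-yl on a nitrogen on an aromatic ring). For the measured compounds named here, no measured pair shows what moving the nitrogen within this ring does, so the expectation rests on compound 3 being at the limit and on compound 1 and compound 2, both of which inhibit growth weakly even with other aromatic groups on that nitrogen. Compound 4 is therefore expected to remain a weak inhibitor, with some chance of again giving only a limit. The step of an at least 1.5-fold lower number from compound 3 to compound 4 (0.17 log units; that floor lies within the scatter) is estimated to be small, if any. Compound 4 is estimated at 100000 nM, within a range from 30000 nM to 250000 nM.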

Compound 4, concentration for 50% growth inhibition: 82400 nM
Compound 4: middle estimate off by 1.2-fold (0.08 log units), on the high side; measured number inside the range.
By their numbers in this assay, from the lowest: compounds 2 and 1 (each within the scatter of the next); then compound 4. At a limit, above all of these: compound 3.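

In this assay, the ring nitrogen decides whether the result is a measured value: with the pyridin-3-yl group, compound 4 gives a number, whereas the pyridin-2-yl group gave only a limit. The move itself reads as an at least 1.8-fold lower number from compound 3 to compound 4 (0.26 log units; that floor lies within the scatter), so the guaranteed part of the change is too small to prove a real gain, even though a number has replaced a limit. Against the 2-bromophenyl group on the same nitrogen, the pyridin-3-yl group still gives weaker growth inhibition, with a 2.9-fold higher number from compound 1 to compound 4 (0.46 log units; beyond the scatter), so among these compounds both pyridinyl groups fall short of 2-bromophenyl.

Going by these compounds, the true size of the nitrogen move stays unknown, since compound 3 is held at a limit rather than a number: the limit of > 150000 nM in this assay, at which 1 of the 4 values shown sits. Also open, on these data alone, is how a pyridin-4-yl group would compare, and whether adding a bromine atom or an amine to the pyridin-3-yl ring would bring growth inhibition back towards that of compound 1.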